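Nitro for trifluoromethyl on a second, larger core

The source may hold more compounds than are shown below. What is called first, only, known or untested is meant among the compounds shown, and "the series" means these compounds.

Three urea compounds have been measured in a functional assay on A2780 cells (Homo sapiens) for inhibition, with a stated time of 72 h; a higher number here means a weaker inhibitor, a lower number a stronger inhibitor. Compound 1 `CC1(C)CCOc2ccc(NC(=O)Nc3ccc([N+](=O)[O-])cc3)cc21` and compound 3 `CC1(C)CCOc2ccc(NC(=O)Nc3ccc(C(F)(F)F)cc3)cc21` share one core and differ only by nitro in place of trifluoromethyl on an aromatic carbon. In this assay compound 3 gives 5000 nM, and compound 1 gives 6700 nM; the step of a 1.3-fold higher number from compound 3 to compound 1 (0.13 log units; within the scatter) is small. Compound 2 `CCC1(CC)CC(C)(C)c2cc(NC(=O)Nc3ccc(C(F)(F)F)cc3)ccc2O1` carries the same trifluoromethyl group on a different core; the difference between the two cores is not broken down here. In this assay compound 2 gives 2450 nM, the lowest of the three numbers.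

Compound 4 `CCC1(CC)CC(C)(C)c2cc(NC(=O)Nc3ccc([N+](=O)[O-])cc3)ccc2O1` has not yet been measured. It stands to compound 2 as compound 1 stands to compound 3: the change is nitro in place of trifluoromethyl on an aromatic carbon, and its place is described in the same words, so it is the same change. Because the earlier step of a 1.3-fold higher number from compound 3 to compound 1 (0.13 log units; within the scatter) stayed within the scatter, a step of similar size is expected, a 1.3-fold higher number from compound 2 to compound 4 (0.12 log units; within the scatter). On that basis compound 4 is estimated at 3200 nM, with a range from 1600 nM to 6500 nM.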

Compound 4, half-maximal inhibitory concentration: 2170 nM
For compound 4 the middle estimate is 1.5-fold (0.17 log units) above the measured one; the measured number falls inside the stated range.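

Putting nitro in place of trifluoromethyl on the core of compound 2 gives a 1.1-fold lower number from compound 2 to compound 4 (0.05 log units; within the scatter) in this assay. Set beside the same change on the core of compound 3, the two steps agree, so on these two cores the change carried across without a visible shift: the same change on two cores in this assay, a 1.3-fold higher number (0.13 log units; within the scatter) from compound 3 to compound 1 and a 1.1-fold lower number (0.05 log units; within the scatter) from compound 2 to compound 4, 1.5-fold (0.18 log units) apart, within the scatter of two such steps This shows only that, on these two cores and in this one assay, the swap leaves the number within the usual scatter; it does not show that nitro and trifluoromethyl can be exchanged on any other core or in any other assay, and it does not explain why the steps are so small.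

Open, as far as these compounds go, is whether a different group in the same place on the aromatic ring, such as an amine, a carboxylic acid or a methoxy group, would move the number. Also open, from the compounds shown here alone, is whether the step would stay this small on a third core or with a longer chain on the core of compound 2.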